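From formyl to propylcarbonyl: compound 3 and compound 4

The source may hold more compounds than are shown below. What is called first, only, known or untested is meant among the compounds shown, and "the series" means these compounds.

Measured in a functional assay on the whole organism for antagonist activity, with Mus musculus as the target; on this read-out lower numbers stand for an effect already at smaller amounts and higher numbers for an effect only at larger amounts of compound:
- Compound 1 `CCC(=O)N(c1ccc(OC)cc1)C1CCCC1N(C)C`: 20 mg/kg; 20 mg/kg (2 entries)
- Compound 2 `CCC(=O)N(c1ccc(C)cc1)C1CCCCC1N(C)C`: > 50 mg/kg (a limit)
- Compound 3 `CN(C)C1CCCC1N(C=O)c1ccccc1`: > 50 mg/kg (a limit)

Compound 3 has no number of its own and sits at the limit of > 50 mg/kg in this assay, at which 2 of the 3 values shown sit. Among the compounds with values here, compound 1 is the only compound with a number, 20 mg/kg; 20 mg/kg (2 entries), the same in both of its entries.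

Compound 4 `CCCC(=O)N(c1ccccc1)C1CCCC1N(C)C` differs from compound 3 in one place: propyl in place of hydrogen on a carbonyl carbon, with propyl in place of hydrogen on a carbonyl carbon. Within the data shown here, no measured pair isolates this change, so the expectation rests on comparison alone. Compound 1, at 20 mg/kg; 20 mg/kg (2 entries), also carries a carbon chain on that carbonyl carbon. Compound 2 goes against this reading, and its > 50 mg/kg is a limit.

The expected change is modest, towards smaller amounts in this assay, and is estimated as an at least 1.6-fold lower number from compound 3 to compound 4 (0.22 log units; that floor lies within the scatter). It may not show if the result again falls at the limit. The estimated value for compound 4 is 30 mg/kg, with an expected range of 12 mg/kg to 75 mg/kg.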

Compound 4, dose for half-maximal effect: 10 mg/kg
Estimate against measurement, compound 4: 3.0-fold (0.48 log units) above; measured number below the stated range.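

In this assay, within the data shown here, propyl in place of hydrogen on a carbonyl carbon gives an at least 5.0-fold lower number from compound 3 to compound 4 (0.69 log units; beyond the scatter), the only measured step at this position. On a carbonyl carbon whose other neighbours are an amide-type nitrogen, the change therefore moves the read-out beyond the scatter, from a limit to a number. The true size of the step stays unknown because compound 3 has only a limit and no number of its own: the limit of > 50 mg/kg in this assay, at which 2 of the 4 values shown sit.

Going by these compounds, whether a longer chain such as butyl, a cyclopropyl group or an amine on that carbonyl carbon would shift the read-out further, or reverse the shift, stays open. Compound 1 and compound 2 differ from compound 4 in more than one place, so they cannot show whether propyl has the same effect on their cores.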